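Thiophene to Fluoropyridine in a Cytotoxicity Series

The source may hold more compounds than are shown below. What is called first, only, known or untested is meant among the compounds shown, and "the series" means these compounds.

Compound 1 `Cc1cnc(Nc2ccc(C#N)cc2)nc1Nc1c(F)cc(-c2cccnc2)cc1F`: 1100 nM
Compound 2 `Cc1cnc(Nc2ccc(C#N)cc2)nc1Nc1c(F)cc(-c2ccsc2)cc1F`: 261000 nM

In a toxicity assay on MT4 cells (Homo sapiens) for cytotoxicity, read by MTT assay, with a stated time of 5 days (on this read-out higher numbers stand for lower toxicity in this test and lower numbers for higher toxicity in this test), compound 2 stands highest of the two measured compounds, at 261000 nM. Compound 3 `Cc1cnc(Nc2ccc(C#N)cc2)nc1Nc1c(F)cc(-c2ccnc(F)c2)cc1F` differs from it by 2-fluoropyridin-4-yl in place of thiophen-3-yl on an aromatic carbon, with 2-fluoropyridin-4-yl in place of thiophen-3-yl on an aromatic carbon. Among the measured compounds shown here, one measured step bears on this change: a 240-fold higher number from compound 1 to compound 2 (2.38 log units; beyond the scatter), a large step on swapping pyridin-3-yl for thiophen-3-yl. The entering group resembles the pyridin-3-yl of compound 1, so a large step down is expected, though probably not all the way to that value. The expected step is a 33-fold lower number from compound 2 to compound 3 (1.51 log units; beyond the scatter). Compound 3 is estimated at 8000 nM, within a range of 1500 nM to 60000 nM.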

Compound 3, half-maximal cytotoxic concentration: 167000 nM
Compound 3: the middle estimate sits 21-fold (1.32 log units) below what was measured; measured number above the stated range.
By their numbers in this assay, from the lowest: compound 1; then compounds 3 and 2 (each within the scatter of the next).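

In this assay, 2-fluoropyridin-4-yl in place of thiophen-3-yl gives a 1.6-fold lower number from compound 2 to compound 3 (0.19 log units; within the scatter), so the five-membered and six-membered rings cannot be told apart in this pair. Against the pyridin-3-yl group, the same entering group gives a 150-fold higher number from compound 1 to compound 3 (2.18 log units; beyond the scatter), which shows that a six-membered aromatic ring with one hetero atom at this position does not by itself bring the number down to that of compound 1. Nothing available here explains why compound 1 stands apart. From the compounds shown here alone, it remains open whether an unfluorinated pyridin-4-yl, a 2-fluoropyridin-3-yl or an amine on the pyridin-3-yl ring would group with compound 1 or with compound 2 and compound 3.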